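The source may hold more compounds than are shown below. What is called first, only, known or untested is meant among the compounds shown, and "the series" means these compounds.

Going by the values given here, in an ADME assay (liver) for metabolic stability, with Liver microsome (Rattus norvegicus) as the target, using microsomes and NADPH, with a stated time of 30 min, tested at 1 uM (a lower number here means slower removal, a higher number faster removal of the compound), compound 2 `COc1cncc(-c2cc(C(O)(C(F)(F)F)C(F)(F)F)cnc2N2CCN(S(=O)(=O)c3ccc(N)nc3)CC2)c1` gives 58 mL.min-1.g-1, the lower of the two numbers so far, while compound 1 `COc1ccc(-c2cc(C(O)(C(F)(F)F)C(F)(F)F)cnc2N2CCN(S(=O)(=O)c3ccc(N)nc3)CC2)cn1` gives 265 mL.min-1.g-1. Next is compound 3 `Nc1ccc(S(=O)(=O)N2CCN(c3ncc(C(O)(C(F)(F)F)C(F)(F)F)cc3-c3ccc4[nH]ncc4c3)CC2)cn1`, which carries 1H-indazol-5-yl in place of 5-methoxypyridin-3-yl on an aromatic carbon. Among the compounds with values here, only one measured step bears on this place, a 4.6-fold lower number from compound 1 to compound 2 (0.66 log units; beyond the scatter), with 5-methoxypyridin-3-yl replacing 6-methoxypyridin-3-yl. That step shows that an exchange here can move this assay beyond the scatter. Within the data shown here, it is only a loose guide, however, as no measured compound carries 1H-indazol-5-yl. With compound 2 holding the lower number, any movement is expected to be upward and no larger than the measured step. The expected change is a 1.7-fold higher number from compound 2 to compound 3 (0.24 log units; within the scatter). For compound 3 the estimate is 100 mL.min-1.g-1, with an expected range of 40 mL.min-1.g-1 to 250 mL.min-1.g-1.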

Compound 3, intrinsic clearance in microsomes: 88 mL.min-1.g-1
Beside the measured number, compound 3's estimate is 1.1-fold (0.06 log units) above it; the range from low to high includes it.
By their numbers in this assay, from the lowest: compounds 2 and 3 (each within the scatter of the next); then compound 1.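

In this assay, exchanging 5-methoxypyridin-3-yl for 1H-indazol-5-yl, which adds a five-membered aromatic ring and a hydrogen-bond donor, gives a 1.5-fold higher number from compound 2 to compound 3 (0.18 log units; within the scatter) and so leaves the read-out within the scatter. Against 6-methoxypyridin-3-yl, the same group gives a 3.0-fold lower number from compound 1 to compound 3 (0.48 log units; beyond the scatter) and compound 1 stands apart from the other two, so this position does not respond to every exchange: two quite different groups give values within the scatter of each other, and compound 1 goes against that pattern. Nothing available here explains these differences.

Open, as far as these compounds go, is how the read-out at this position responds to a plain phenyl, a morpholine or a carboxylic acid. Also open, from the compounds shown here alone, is whether 1-methyl-1H-indazol-5-yl, which lacks the ring hydrogen-bond donor, would stay with compound 3.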